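This account rests on a few compounds, and the source may have more. Where it says the series, first, only, none or still open, it means among the compounds named here.

Of the compounds shown here, three from one series have been tested for their effect on growth of a breast-cancer cell line, in a functional assay on MCF7 cells (Homo sapiens) for inhibition, read by fluorescence, with a stated time of 72 h; on this read-out higher numbers stand for weaker inhibition of growth and lower numbers for stronger inhibition of growth. Compound 1 `CC(C)CCn1cnc2c(Nc3ccc(Cl)cc3)nc(N[C@H]3CC[C@H](N)CC3)nc21` gives 2700 nM in this assay. Compound 2 `COc1cc(Nc2nc(N[C@H]3CC[C@H](N)CC3)nc3c2ncn3CCC(C)C)cc(OC)c1` gives 4500 nM, and compound 3 `CCCCn1cnc2c(Nc3cc(OC)cc(OC)c3)nc(N[C@H]3CC[C@H](N)CC3)nc21` gives 4500 nM.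

Compound 2 and compound 3 share one core that differs only in a side chain: hydrogen in place of methyl on a saturated chain carbon bound to two saturated chain carbons. This change made no change at the digits printed from compound 2 to compound 3 (within the scatter), so the two numbers are read as the same.

Compound 1 differs from compound 2 in the group carried on a ring nitrogen: 4-chlorophenyl in place of 3,5-dimethoxyphenyl on a nitrogen on an aromatic ring. That change gave a 1.7-fold lower number from compound 2 to compound 1 (0.22 log units; within the scatter), a step too small to count as a real difference.

Compound 4 `CCCCn1cnc2c(Nc3ccc(Cl)cc3)nc(N[C@H]3CC[C@H](N)CC3)nc21` has not been measured. It stands to compound 3 exactly as compound 1 stands to compound 2: 4-chlorophenyl in place of 3,5-dimethoxyphenyl on a nitrogen on an aromatic ring. The place of the change is the same in both pairs, so this is the same change made on the other core. Because the earlier step was a 1.7-fold lower number from compound 2 to compound 1 (0.22 log units; within the scatter), a step of about that size is expected here too, which means the number for compound 4 is estimated to land near that of compound 1, with the chance that it comes out anywhere from level with compound 3 to somewhat lower. Compound 4 is expected to give an estimated 2800 nM in this assay, between 1200 nM and 6500 nM, an expected step of a 1.6-fold lower number from compound 3 to compound 4 (0.21 log units; within the scatter).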

Compound 4, concentration for 50% growth inhibition: 2100 nM
Compound 4: middle estimate off by 1.3-fold (0.12 log units), on the high side; the measured number falls inside the stated range.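

In this assay, putting 4-chlorophenyl in place of 3,5-dimethoxyphenyl gave a 2.1-fold lower number from compound 3 to compound 4 (0.33 log units; beyond the scatter), a modest step, and it agrees with the same change on the other core: the same change on two cores in this assay, a 1.7-fold lower number (0.22 log units; within the scatter) from compound 2 to compound 1 and a 2.1-fold lower number (0.33 log units; beyond the scatter) from compound 3 to compound 4, 1.3-fold (0.11 log units) apart, within the scatter of two such steps. The side-chain change, hydrogen in place of methyl, gave a 1.3-fold lower number from compound 1 to compound 4 (0.11 log units; within the scatter), and it too agrees with its earlier counterpart: the same change on two cores in this assay, no change at the digits printed (within the scatter) from compound 2 to compound 3 and a 1.3-fold lower number (0.11 log units; within the scatter) from compound 1 to compound 4, 1.3-fold (0.11 log units) apart, within the scatter of two such steps. Within these four compounds, then, each change behaved alike on both cores, but this rests on a single pair of steps per change, only one of the four steps lies beyond the scatter, and nothing here shows that the same would hold on any other core or explains why the numbers move as they do.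

The compounds shown leave open whether the aryl change would hold up with a different group on that nitrogen, such as a carboxylic acid on the phenyl ring or a plain unsubstituted phenyl, and whether a much longer chain or one ending in an amine would leave the number as unmoved as the loss of one methyl did. They also leave open whether any such group could bring a step clearly larger than the modest one seen here.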